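The source may report more compounds than this note shows. Statements on the series, on what has been measured and on what is new or still open speak of the compounds shown alone.

In an ADME assay on Caco-2 cells (Homo sapiens) for permeability, read by LC-MS, with a stated time of 2 h (on this read-out lower numbers stand for lower permeability and higher numbers for higher permeability), compound 3 (`CCN(Cc1ccc(OCCn2c(=O)ccn(C)c2=O)c(C)c1)C(CC(=O)O)c1ccc(Cl)cc1`) gives 2.1 nm/s as the second highest of three numbers, with compound 2 (`Cc1cc(CN(C)C(CC(=O)O)c2ccc(Cl)cc2)ccc1OCCn1c(=O)ccn(C)c1=O`) at 0.6 nm/s on the low side and compound 1 (`CCCN(Cc1ccc(OCCN2C(=O)CCC2=O)c(C)c1)C(CC(=O)O)c1ccc(Cl)cc1`) at 10.2 nm/s on the high side. Compound 4 (`CCCN(Cc1ccc(OCCn2c(=O)ccn(C)c2=O)c(C)c1)C(CC(=O)O)c1ccc(Cl)cc1`) differs from compound 3 by methyl in place of hydrogen on a saturated chain carbon, two bonds along the chain from an amine nitrogen in the form of methyl in place of hydrogen on a saturated chain carbon, two bonds along the chain from an amine nitrogen, which reads as ethyl to propyl. Among the compounds with values here, only one measured step bears on this, the methyl to ethyl change: a 3.5-fold higher number from compound 2 to compound 3 (0.54 log units; beyond the scatter) is modest and lies beyond the scatter. In this assay a rise of similar modest size is therefore expected, though a single step is thin support. The expected step is a 2.1-fold higher number from compound 3 to compound 4 (0.33 log units; beyond the scatter) as estimated from that one precedent. For compound 4 the estimate is 4.5 nm/s with 2.2 nm/s to 9.5 nm/s as the expected range.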

Compound 4, apparent permeability: 3.2 nm/s
Beside the measured number, compound 4's estimate is 1.4-fold (0.15 log units) above it; the measured number falls inside the stated range.
By their numbers in this assay, from the lowest: compound 2; then compounds 3 and 4 (each within the scatter of the next); then compound 1.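

In this assay, the ethyl to propyl change gives a 1.5-fold higher number from compound 3 to compound 4 (0.18 log units; within the scatter), so the rise seen for methyl to ethyl, a 3.5-fold higher number from compound 2 to compound 3 (0.54 log units; beyond the scatter), does not recur beyond the scatter at this position, although the full span from methyl to propyl gives a 5.3-fold higher number from compound 2 to compound 4 (0.73 log units; beyond the scatter). With propyl held constant, exchanging the ring-bearing group gives a 3.2-fold lower number from compound 1 to compound 4 (0.50 log units; beyond the scatter), so that change also moves the number beyond the scatter. Nothing available explains either step.

Still open, on these data alone, is how a butyl or longer chain, or a branched isopropyl group, would read at this position. Also open, as far as these compounds go, is whether the ring-bearing group of compound 1 would give a similar step with an ethyl or methyl group in place of propyl.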